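The compounds below may be only part of what the source reports. "The series", "measured", "known", "first", "only" and "open" are said of these compounds alone.

Measured in a physicochemical assay for permeability, using PAMPA, at pH 7.4 (a higher number here means that the compound crosses the layer faster, a lower number that the compound crosses the layer more slowly), so far:

Compound 3 `CS(=O)(=O)NC(=O)c1ccc(Nc2nc(NC3(c4ccc(Cl)cc4)CC3)nc(OCC(F)(F)F)n2)cc1` gives 11 nm/s.
Compound 1 `CC(C)S(=O)(=O)NC(=O)c1ccc(Nc2nc(NC3(c4ccc(Cl)cc4)CC3)nc(OCC(F)(F)F)n2)cc1` gives 31 nm/s.
Compound 2 `CC(C)(C)CNCCS(=O)(=O)NC(=O)c1ccc(Nc2nc(NC3(c4ccc(Cl)cc4)CC3)nc(OCC(F)(F)F)n2)cc1` gives 651 nm/s.

Compound 3 has the lowest number of the three. The nearest is compound 1: the step is a 2.8-fold lower number from compound 1 to compound 3 (0.45 log units; beyond the scatter). The furthest is compound 2: the step is a 59-fold lower number from compound 2 to compound 3 (1.77 log units; beyond the scatter).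

Compound 4 is `NCCS(=O)(=O)NC(=O)c1ccc(Nc2nc(NC3(c4ccc(Cl)cc4)CC3)nc(OCC(F)(F)F)n2)cc1`. Its difference from compound 3 is aminomethyl in place of hydrogen on a saturated chain carbon bound to a sulfonyl sulfur. This is the same place on the chain where compound 2 carries its larger group, so the two steps that bear on it are a 59-fold lower number from compound 2 to compound 3 (1.77 log units; beyond the scatter) and a 21-fold higher number from compound 1 to compound 2 (1.32 log units; beyond the scatter), both large, both pointing toward a higher number when a group carrying an amine sits on that chain carbon. The aminomethyl group entering here is shorter than the (neopentylamino)methyl group of compound 2, so a rise is expected in this assay, but a smaller one. Compound 4 is therefore estimated at 60 nm/s, with a range from 15 nm/s to 250 nm/s. The expected step is a 5.5-fold higher number from compound 3 to compound 4 (0.74 log units; beyond the scatter).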

Compound 4, apparent permeability: 153 nm/s
Beside the measured number, compound 4's estimate is 2.6-fold (0.41 log units) below it; the range from low to high includes it.
By their numbers in this assay, from the lowest: compound 3; then compound 1; then compound 4; then compound 2.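

In this assay the aminomethyl group alone gives a 14-fold higher number from compound 3 to compound 4 (1.14 log units; beyond the scatter) on this chain carbon, so the neopentyl group of compound 2 is not required for a large rise. That neopentyl group still adds to the number: hydrogen in its place on the amine nitrogen gives a 4.3-fold lower number from compound 2 to compound 4 (0.63 log units; beyond the scatter) and shows the amine nitrogen as a second place where this read-out moves. Measured against isopropyl on the sulfonyl sulfur, 2-aminoethyl gives a 4.9-fold higher number from compound 1 to compound 4 (0.69 log units; beyond the scatter) as well, so the rise does not depend on methyl as the starting group. Nothing shown here accounts for these steps.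

Still open, on these data alone, is whether the amine or the longer chain goes with the rise; a plain propyl chain or a 2-hydroxyethyl chain on the sulfonyl sulfur would separate the two. A methyl group on the amine nitrogen would show how the number changes between hydrogen and neopentyl.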